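Methylamino to dimethylamino on the thiophene-bearing core

The source may report more compounds than this note shows. Statements on the series, on what has been measured and on what is new or still open speak of the compounds shown alone.

Compound 3 `CNc1ncnc2c1c(-c1cccs1)cn2[C@@H]1O[C@H](CO)[C@@H](O)[C@H]1O` is read in a functional assay on HCT-116 cells (Homo sapiens), read by MTT assay, with a stated time of 72 h (on this read-out lower numbers stand for stronger inhibition and higher numbers for weaker inhibition), where compound 3 gives only a limit, > 20000 nM. The same limit is reached by compound 1 `CN(C)c1ncnc2c1c(-c1ccoc1)cn2[C@@H]1O[C@H](CO)[C@@H](O)[C@H]1O`, which in this assay gives > 20000 nM. Compound 2 `COc1ncnc2c1c(-c1cccs1)cn2[C@@H]1O[C@H](CO)[C@@H](O)[C@H]1O` stands apart: in this assay compound 2 gives 80 nM, and the step of an at least 250-fold higher number from compound 2 to compound 3 (2.39 log units; beyond the scatter) is the only measured one here; its size rests on (the limit of > 20000 nM in this assay, at which 2 of the 3 values shown sit). Compound 4 `CN(C)c1ncnc2c1c(-c1cccs1)cn2[C@@H]1O[C@H](CO)[C@@H](O)[C@H]1O` differs from compound 3 by methyl in place of hydrogen on a nitrogen on an aromatic ring. Within the data shown here, no measured step covers methylamino to dimethylamino; compound 1 shows that dimethylamino on the furan-bearing core sits at the limit as well. The step that the limit leaves unreadable from compound 3 to compound 4 is therefore expected to stay within the scatter, and for compound 4 a value of about 25000 nM is estimated, most likely again a limit, within 8000 nM to 100000 nM.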

Compound 4, half-maximal inhibitory concentration: > 20000 nM
Compound 4 was reported as a limit (the forecaster's own chance of this, stated with the estimate: 80%); the middle value is on the limit's open side.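

In this assay compound 4 gives > 20000 nM, which is a limit of the assay. Dimethylamino in place of methoxy gives an at least 250-fold higher number from compound 2 to compound 4 (2.39 log units; beyond the scatter), so methylamino and dimethylamino on this core both reach the limit, while methoxy alone gives a measured value. The steps that join two limits cannot be read, and no order can be set among compound 1, compound 3 and compound 4: the limit of > 20000 nM in this assay, at which 3 of the 4 values shown sit.

From the compounds shown here alone, what ethoxy or an unsubstituted amino group would give at this position stays open. Going by these compounds, how far the true values of compound 1, compound 3 and compound 4 lie beyond the limit also stays open.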